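The compounds below may be only part of what the source reports. "The series", "measured", "known", "first", "only" and "open" are said of these compounds alone.

Measured in an ADME assay on MT4 cells (Homo sapiens) for cytotoxicity, read by MTT assay; on this read-out lower numbers stand for higher toxicity in this test and higher numbers for lower toxicity in this test:

Compound 1 `O=C1c2ccccc2C(=O)N1CCOC(=S)N(C(=O)c1cccc([N+](=O)[O-])c1)c1ccc(Cl)cc1`: 18000 nM
Compound 2 `O=C1c2ccccc2C(=O)N1CCOC(=S)N(C(=O)c1ccc(C(F)(F)F)cc1)c1ccc(Cl)cc1`: 10000 nM
Compound 3 `O=C1c2ccccc2C(=O)N1CCOC(=S)N(C(=O)c1cccc(Cl)c1Cl)c1ccc(Cl)cc1`: 54000 nM

Compound 3 stands highest of the three, with a 3.0-fold higher number from compound 1 to compound 3 (0.48 log units; beyond the scatter) and a 5.4-fold higher number from compound 2 to compound 3 (0.73 log units; beyond the scatter), both beyond the scatter and both modest. Compound 4 `O=C1c2ccccc2C(=O)N1CCOC(=S)N(C(=O)c1ccc2ccccc2c1)c1ccc(Cl)cc1` differs from compound 3 in one place: naphthalen-2-yl in place of 2,3-dichlorophenyl on a carbonyl carbon. For the measured compounds named here, no measured step exchanges 2,3-dichlorophenyl for naphthalen-2-yl; the only steps on this carbonyl carbon are the two that brought 2,3-dichlorophenyl into compound 3, and both raised the number. Its departure is therefore expected to lower the number modestly, back toward where compound 1 and compound 2 sit. The expected step is a 2.7-fold lower number from compound 3 to compound 4 (0.43 log units; beyond the scatter). Compound 4 is expected to give 20000 nM in this assay, with a likely range of 8000 nM to 50000 nM.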

Compound 4, half-maximal cytotoxic concentration: 37000 nM
Compound 4: the middle estimate sits 1.9-fold (0.27 log units) below what was measured; the measured number falls inside the stated range.
By their numbers in this assay, from the lowest: compounds 2 and 1 (each within the scatter of the next); then compounds 4 and 3 (each within the scatter of the next).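

In this assay the exchange of 2,3-dichlorophenyl for naphthalen-2-yl on this carbonyl carbon gives a 1.5-fold lower number from compound 3 to compound 4 (0.16 log units; within the scatter) and does not separate the two compounds. Naphthalen-2-yl also stands clear of the other two groups, with a 3.7-fold higher number from compound 2 to compound 4 (0.57 log units; beyond the scatter) and a 2.1-fold higher number from compound 1 to compound 4 (0.31 log units; beyond the scatter), so among these compounds the higher numbers at this position do not require chlorine on the group. Nothing at hand explains these differences. As far as these compounds go, all four compounds carry an aromatic group here, so it remains open how a cyclohexyl ring, an amine or a carboxylic acid at this position would read.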